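The source may hold more compounds than are shown below. What is called first, only, known or untested is meant among the compounds shown, and "the series" means these compounds.

Measured compounds:
- compound 1, `COc1cc(-c2cc(/C=C/C(=O)c3ccc(N)cc3)[nH]n2)cc(OC)c1OC`: -35%
- compound 2, `COc1ccc(-c2cc(/C=C/C(=O)c3ccc(N)cc3)[nH]n2)cc1OC`: -81%
- compound 3, `COc1cc(C(=O)/C=C/c2cc(-c3cc(OC)c(OC)c(OC)c3)n[nH]2)cc(OC)c1OC`: -95%

Compound 1 and compound 2 share a core and differ by hydrogen in place of methoxy on an aromatic carbon. In a functional assay on HOP-92 cells (Homo sapiens) for cytotoxicity, read by sulforhodamine B assay, with a stated time of 48 h, tested at 100 uM (on this read-out lower numbers stand for a stronger effect and higher numbers for a weaker effect at the one concentration tested), the step of a number 46 percentage points lower from compound 1 to compound 2 (beyond the scatter). Compound 3, with the lowest of the three numbers, is built on a different core; the difference between the two cores is not broken down here. Compound 4, `COc1ccc(-c2cc(/C=C/C(=O)c3cc(OC)c(OC)c(OC)c3)[nH]n2)cc1OC`, is not yet measured. Going by the values given here, it differs from compound 3 by hydrogen in place of methoxy on an aromatic carbon, the same change as the one from compound 1 to compound 2. The earlier step moved the read-out a long way. For compound 3 the number already stands close to the floor of this assay, so only a small step to compound 4 is expected, a number 2 percentage points lower from compound 3 to compound 4 (within the scatter). Compound 4 is therefore estimated at -97%, between -100% and -82%.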

Compound 4, a percentage reported as activity, at one concentration (the size of the read-out at that concentration, not a potency): -84%
Beside the measured number, compound 4's estimate is 13 percentage points below it; measured number inside the range.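

In this assay, hydrogen in place of methoxy on an aromatic carbon gives a number 11 percentage points higher from compound 3 to compound 4 (beyond the scatter), so the change does not carry over between these two cores with a fixed size or direction: the same change on two cores in this assay, a number 46 percentage points lower (beyond the scatter) from compound 1 to compound 2 and a number 11 percentage points higher (beyond the scatter) from compound 3 to compound 4, 57 percentage points apart, beyond the scatter of two such steps

This shows that the step on one core cannot be used to predict the step on the other within this pair of cores. It does not show why the two steps differ, and two cores set no rule for any further core.

The compounds shown carry only methoxy or hydrogen at this aromatic carbon, so the outcome with a hydroxyl group or a chlorine atom there remains open. Also open, on these data alone, is whether the contrast holds at other concentrations.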